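This account rests on a few compounds, and the source may have more. Where it says the series, first, only, none or still open, it means among the compounds named here.

Compound 2 `CC(C)C[C@H](N)c1cc(C(F)(F)F)ccc1N1CCN(C(=O)CCNC2CCCCC2)CC1` is the weakest of the three measured compounds in an assay on HEK293 cells for displacement of a labelled ligand from Melanocortin receptor 4 (Homo sapiens); a higher number here means a weaker inhibitor, a lower number a stronger inhibitor: compound 2 gives 4800 nM, whereas compound 1 `CC(C)C[C@H](N)c1ccccc1N1CCN(C(=O)[C@H](C)Cc2ccc(Cl)cc2F)CC1` gives 67 nM and compound 3 `CC(C)C[C@H](N)c1ccccc1N1CCN(C(=O)[C@H](C)Cc2ccc(Cl)cc2Cl)CC1` gives 16 nM. Compound 4 `COc1ccc(CC(C)C(=O)N2CCN(c3ccc(C(F)(F)F)cc3[C@@H](N)CC(C)C)CC2)cc1F` differs from compound 2 in one place: 1-(3-fluoro-4-methoxybenzyl)ethyl in place of 2-(cyclohexylamino)ethyl on a carbonyl carbon. For the measured compounds named here, no measured step covers this exchange directly. Going by the values given here, the only measured step, a 4.2-fold lower number from compound 1 to compound 3 (0.62 log units; beyond the scatter), is a change of substituent on an aromatic ring of the same kind as the one that enters with compound 4, and it shows that such a change moves the number only modestly. What compounds 1 and 3 do show is that a group of the kind entering compound 4, built on a six-membered aromatic ring, sits on the same carbonyl carbon in both of them, and both give far lower numbers than compound 2. Compound 4 keeps the trifluoromethyl group of compound 2, which compounds 1 and 3 lack, so the comparison is not exact. The expected step is therefore a 24-fold lower number from compound 2 to compound 4 (1.38 log units; beyond the scatter), a large drop in the number. Compound 4 is estimated at 200 nM, with a likely range from 40 nM to 1000 nM.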

Compound 4, inhibition constant: 200 nM
Compound 4: middle estimate and measured number agree at the digits printed; the range from low to high includes it.
By their numbers in this assay, from the lowest: compound 3; then compound 1; then compound 4; then compound 2.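

For the compounds shown here, this is the first comparison of the two groups on a carbonyl carbon whose other neighbour is an amide-type nitrogen in a ring, with the rest of the molecule, trifluoromethyl included, held constant. Compound 2 differs from compounds 1 and 3 in more than one place, so those earlier values could not isolate the effect of this group, whereas in this assay the exchange alone gives a 24-fold lower number from compound 2 to compound 4 (1.38 log units; beyond the scatter). Nothing available explains this drop.

The exchange alters several things at once: a non-aromatic ring gives way to an aromatic one, the nitrogen and its hydrogen-bond donor leave, and fluoro and methoxy substituents enter, and the compounds shown do not separate these changes. A 2-(phenylamino)ethyl group would keep the nitrogen while carrying an aromatic ring, and a 1-(cyclohexylmethyl)ethyl group would have a non-aromatic ring without the nitrogen, so either could show which of these features matters more at this position.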